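The source may hold more compounds than are shown below. What is called first, only, known or untested is meant among the compounds shown, and "the series" means these compounds.

Of the compounds shown here, two in this set have been tested in an assay on RBL-1 cells for inhibition of Polyunsaturated fatty acid 5-lipoxygenase (Rattus norvegicus); a higher number here means a weaker inhibitor, a lower number a stronger inhibitor. Compound 1 `CCc1cccc(N2CCNC(=O)N2)c1` carries an ethyl group on its benzene ring, and in this assay compound 1 gives 13000 nM. Compound 2 `COc1cccc(N2CC(C)NC(=O)N2)n1` differs from compound 1 in more than one place, and in this assay compound 2 gives 5500 nM. Of the two numbers, compound 1 has the higher one, so it is the weaker inhibitor of the pair, and the gap lies beyond the usual scatter.

Compound 3 `O=C1NCCN(c2cccc(-c3nccs3)c2)N1` has not yet been measured. It differs from compound 1 in one place: 1,3-thiazol-2-yl in place of ethyl on an aromatic carbon. A flat five-membered aromatic ring with two heteroatoms takes the place of a short two-carbon chain. Going by the values given here, since no other step in the set shows how this assay responds to that kind of change, the expected step from compound 1 to compound 3 is a modest gain in potency, a 2.6-fold lower number from compound 1 to compound 3 (0.41 log units; beyond the scatter), worth somewhat more than the scatter. Compound 3 is therefore expected to give about 5000 nM in this assay, with a likely range from 1500 nM to 15000 nM.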

Compound 3, half-maximal inhibitory concentration: 35000 nM
Beside the measured number, compound 3's estimate is 7.0-fold (0.85 log units) below it, outside the stated range (above it).
By their numbers in this assay, from the lowest: compound 2; then compound 1; then compound 3.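

In this assay, placing 1,3-thiazol-2-yl in place of ethyl on this aromatic carbon gives a 2.7-fold higher number from compound 1 to compound 3 (0.43 log units; beyond the scatter), a modest loss of potency. Going by these compounds alone, this is the first direct sign that the position is not indifferent to what sits on it: the swap brings in a five-membered aromatic ring with two hydrogen-bond acceptors, and the inhibitor gets weaker rather than stronger. Nothing available here explains why the number rises.

A single step cannot show whether the loss follows the added ring as such or the nitrogen and sulfur within it. From the compounds shown here alone, how a plain phenyl ring, with no hetero atoms, or a longer chain such as propyl would behave on this same carbon remains open.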